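The compounds below may be only part of what the source reports. "The series", "measured", "known", "first", "only" and "open" are said of these compounds alone.

Compound 3, `O=C(/C(=C\c1c(O)cc(O)cc1O)Sc1ccc(Br)cc1)c1ccc(Cl)cc1`, is where this step begins. In a functional assay on DU-145 cells (Homo sapiens) for inhibition, read by trypan blue exclusion, with a stated time of 96 h (on this read-out higher numbers stand for weaker inhibition of growth and lower numbers for stronger inhibition of growth), compound 3 gives 50000 nM. Compound 2, `O=C(/C(=C\c1ccc(O)cc1O)Sc1ccc(Br)cc1)c1ccc(Cl)cc1`, gives 50000 nM in this assay, and the step of no change at the digits printed from compound 2 to compound 3 (within the scatter) leaves compound 3 level with compound 2. Compound 1, `CN(C)c1ccc(/C=C(/Sc2ccc(Br)cc2)C(=O)c2ccc(Cl)cc2)cc1`, in this assay gives > 100000 nM, which is a limit of the assay and not a number. From that limit the steps of an at least 2.0-fold lower number from compound 1 to compound 2 (0.30 log units; that floor lies within the scatter) and an at least 2.0-fold lower number from compound 1 to compound 3 (0.30 log units; that floor lies within the scatter) run, both changing the group on the double-bonded chain carbon bound to a double-bonded chain carbon.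

Compound 4, `Cc1ccc(S(=O)(=O)/C(=C/c2c(O)cc(O)cc2O)C(=O)c2ccc(Cl)cc2)cc1`, differs from compound 3 as follows: (4-methylphenyl)sulfonyl in place of (4-bromophenyl)sulfanyl on a double-bonded chain carbon bound to a carbonyl carbon and a double-bonded chain carbon. Among the measured compounds shown here, no measured step changes the group on the double-bonded chain carbon bound to a carbonyl carbon and a double-bonded chain carbon, so the three measured values offer no guide to this change. For compound 4 the estimated step in this assay is no change at the digits printed from compound 3 to compound 4 (within the scatter), none beyond the scatter. Compound 4 is therefore expected to give 50000 nM, within 15000 nM to 100000 nM.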

Compound 4, concentration for 50% growth inhibition: > 100000 nM
Compound 4 was reported as a limit (the forecaster's own chance of this, stated with the estimate: 30%); at least 2.0-fold (0.30 log units) between middle value and limit.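

Moving from (4-bromophenyl)sulfanyl to (4-methylphenyl)sulfonyl on the double-bonded chain carbon bound to a carbonyl carbon and a double-bonded chain carbon gives the first measured step at this position in this assay: an at least 2.0-fold higher number from compound 3 to compound 4 (0.30 log units; that floor lies within the scatter). Compound 4 gives > 100000 nM, which is a limit of the assay and not a number. This change brought no stronger inhibition of growth, but a loss beyond the scatter is not established, and the reading stops at the assay's limit: the limit of > 100000 nM in this assay, at which 2 of the 4 values shown sit.

The sulfur and the ring substituent changed together, so the compounds shown cannot assign the step to either one; (4-bromophenyl)sulfonyl or (4-methylphenyl)sulfanyl would separate them. On these data alone, how an amine or a carboxylic acid on the aryl ring at this position would read also remains open.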